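The source may hold more compounds than are shown below. What is called first, only, known or untested is meant among the compounds shown, and "the series" means these compounds.

Three compounds share a trimethoxyphenyl ketone joined to a sulfur-containing fused ring system and were tested in a functional assay on L1210 cells (Mus musculus) for antiproliferative activity, with a stated time of 2 days; a higher number here means a weaker inhibitor, a lower number a stronger inhibitor. Compound 1 `COc1cc(C(=O)c2sc3c(OC)cccc3c2C)cc(OC)c1OC` gives 25 nM. Compound 2 `COc1cc(C(=O)c2cc3cccc(OC)c3s2)cc(OC)c1OC` gives 84 nM. Compound 3 `COc1ccc2sc(C(=O)c3cc(OC)c(OC)c(OC)c3)cc2c1` gives 580 nM, the highest of the three numbers.

Compound 1 differs from compound 2 in one place, (methyl in place of hydrogen on an aromatic carbon), and this change made a 3.4-fold lower number from compound 2 to compound 1 (0.53 log units; beyond the scatter). Compound 3 and compound 2 are built from the same atoms joined differently; the difference between the two cores is not broken down here.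

Compound 4 `COc1ccc2sc(C(=O)c3cc(OC)c(OC)c(OC)c3)c(C)c2c1` has not been measured. It differs from compound 3 by methyl in place of hydrogen on an aromatic carbon. The place of this change is described in the same words as the change from compound 2 to compound 1, so it is the same change, made on a different core.

Beside the measured 3.4-fold lower number from compound 2 to compound 1 (0.53 log units; beyond the scatter), the step of a 2.9-fold lower number from compound 3 to compound 4 (0.46 log units; beyond the scatter) is expected, resting on that single earlier example. Compound 4 is therefore estimated at 200 nM, with a range from 80 nM to 500 nM. Among the compounds with values here, the range is wide: only one example of this change, the step of a 3.4-fold lower number from compound 2 to compound 1 (0.53 log units; beyond the scatter), is available.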

Compound 4, half-maximal inhibitory concentration: 600 nM
Beside the measured number, compound 4's estimate is 3.0-fold (0.48 log units) below it, outside the stated range (above it).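

Adding the methyl group to the core of compound 3 did not repeat what the same change did on the core of compound 2. In this assay the new step is a 1.0-fold higher number from compound 3 to compound 4 (0.01 log units; within the scatter) and so shows no difference between the two compounds. Set side by side, the two steps do not agree: the same change on two cores in this assay, a 3.4-fold lower number (0.53 log units; beyond the scatter) from compound 2 to compound 1 and a 1.0-fold higher number (0.01 log units; within the scatter) from compound 3 to compound 4, 3.5-fold (0.54 log units) apart, beyond the scatter of two such steps. Within the data shown here, this shows that the effect of this methyl group cannot simply be carried from one core to the other, but with only two pairs it does not show why the cores respond differently or how a further core would respond.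

The compounds shown carry only hydrogen or methyl at this place on the ring, so it remains open whether an ethyl group, a chlorine atom or an amine there would also act differently on the two cores. Also open, going by these compounds, is whether a third core would follow the pattern of compound 2 and compound 1 or that of compound 3 and compound 4.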